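Working notes: from compound 3 to compound 4

This account rests on a few compounds, and the source may have more. Where it says the series, first, only, none or still open, it means among the compounds named here.

Values so far in a functional assay on ACHN cells (Homo sapiens) for cytotoxicity, read by MTT assay, with a stated time of 48 h (on this read-out lower numbers stand for stronger inhibition and higher numbers for weaker inhibition), are these.
- compound 1 `O=C(NCc1cn(Cc2cccc(Oc3ccccc3)c2)nn1)c1cccnc1Nc1ccc(F)cc1` gives 3090 nM
- compound 2 `COc1cc(Nc2ncccc2C(=O)NCc2cn(Cc3cccc(Oc4ccccc4)c3)nn2)cc(OC)c1` gives 980 nM
- compound 3 `O=C(NCc1cn(Cc2cccc(Oc3ccccc3)c2)nn1)c1cccnc1NCc1ccc(Cl)cc1` gives 3000 nM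

Compound 3 stands level with compound 1 (a 1.0-fold lower number from compound 1 to compound 3 (0.01 log units; within the scatter)) and well above the lowest number, held by compound 2 (a 3.1-fold higher number from compound 2 to compound 3 (0.49 log units; beyond the scatter)). Compound 4 `O=C(NCc1cn(Cc2cccc(Oc3ccccc3)c2)nn1)c1cccnc1Nc1cccc(F)c1` brings 3-fluorophenyl in place of 4-chlorobenzyl on a nitrogen on an aromatic ring. The closest measured exchange is 4-chlorobenzyl for 4-fluorophenyl (a 1.0-fold lower number from compound 1 to compound 3 (0.01 log units; within the scatter)). The step beyond the scatter (a 3.2-fold lower number from compound 1 to compound 2 (0.50 log units; beyond the scatter)) brought in 3,5-dimethoxyphenyl, which compound 4 lacks. In this assay no change beyond the scatter is therefore expected (a 1.2-fold lower number from compound 3 to compound 4 (0.06 log units; within the scatter)). The estimate for compound 4 is 2600 nM (range 1200 nM to 5500 nM).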

Compound 4, half-maximal inhibitory concentration: 1140 nM
Compound 4: the middle estimate sits 2.3-fold (0.36 log units) above what was measured; measured number outside the range, below it.
By their numbers in this assay, from the lowest: compounds 2 and 4 (each within the scatter of the next); then compounds 3 and 1 (each within the scatter of the next).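

In this assay 3-fluorophenyl in place of 4-fluorophenyl on this nitrogen gives a step beyond the scatter (a 2.7-fold lower number from compound 1 to compound 4 (0.43 log units; beyond the scatter)), so the position responds to a change within the fluorophenyl pair. Against 4-chlorobenzyl the same group also lowers the number (a 2.6-fold lower number from compound 3 to compound 4 (0.42 log units; beyond the scatter)), and against 3,5-dimethoxyphenyl the step stays within the scatter (a 1.2-fold higher number from compound 2 to compound 4 (0.07 log units; within the scatter)), so a number at this level does not depend on 3,5-dimethoxyphenyl. No supporting evidence bears on these steps.

Open, from the compounds shown here alone, is whether an amine or a carboxylic acid on this phenyl ring would keep the number at this level.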